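Isopropyl to methyl: compound 2 to compound 3

The compounds below may be only part of what the source reports. "The series", "measured", "known", "first", "only" and "open" are said of these compounds alone.

For the measured compounds named here, in a functional assay on NCI-H460 cells (Homo sapiens) for antiproliferative activity, read by MTT assay, with a stated time of 24 h (a higher number here means a weaker inhibitor, a lower number a stronger inhibitor), compound 2 `Cc1cc(=O)n2nc(SCc3ccc(C(C)C)cc3)nc2[nH]1` gives 31800 nM, the only actual number so far. Compound 1 `Cc1cc(=O)n2nc(SCc3ccc(F)cc3)nc2[nH]1` gives only a limit, > 80000 nM. Isopropyl in place of fluoro gave an at least 2.5-fold lower number from compound 1 to compound 2 (0.40 log units; beyond the scatter), a size open on one side given (the limit of > 80000 nM in this assay, at which 1 of the 2 values shown sits). Compound 3 `Cc1ccc(CSc2nc3[nH]c(C)cc(=O)n3n2)cc1` carries methyl in place of isopropyl on an aromatic carbon. With that single step as the guide, part of it is expected to be lost in this assay, moving towards a higher number. The expected change is a 1.7-fold higher number from compound 2 to compound 3 (0.24 log units; within the scatter). For compound 3 the estimated value is 55000 nM, within an expected range of 30000 nM to 90000 nM.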

Compound 3, half-maximal inhibitory concentration: 49900 nM
Compound 3: the middle estimate sits 1.1-fold (0.04 log units) above what was measured; the measured number falls inside the stated range.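

In this assay methyl in place of isopropyl on the aromatic carbon gives a 1.6-fold higher number from compound 2 to compound 3 (0.20 log units; within the scatter) and so does not separate the two groups at this position. Methyl in place of fluoro gives an at least 1.6-fold lower number from compound 1 to compound 3 (0.20 log units; that floor lies within the scatter) and so, read alone, does not set methyl apart from fluoro. That step rests on a limit and not on a number: the limit of > 80000 nM in this assay, at which 1 of the 3 values shown sits.

The compounds shown leave open how an amine or a carboxylic acid on this aromatic carbon would read, and whether a longer chain there would move the number beyond the scatter.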